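The compounds below may be only part of what the source reports. "The series", "measured", "known", "first", "only" and "open" are said of these compounds alone.

Compound 1 `CC[C@@H](CCn1cncn1)c1ccc(C)cc1` and compound 2 `CC[C@@H](CCn1cncn1)c1ccc(OC)cc1` share one core and differ only on the aromatic ring. In an ADME assay on RD cells (Homo sapiens) for cytotoxicity, read by MTT assay, with a stated time of 3 days (a higher number here means that more compound is tolerated, a lower number that less compound is tolerated), compound 1 gives 79.4 ug/mL, and compound 2 gives 115 ug/mL; the step of a 1.4-fold higher number from compound 1 to compound 2 (0.16 log units; within the scatter) is the only one measured so far. Compound 1 therefore stands at the lower of the two numbers in this assay, with the step to compound 2 within the scatter. Compound 3 `CCC[C@@H](CCn1cncn1)c1ccc(C)cc1` is the next compound, and it is not yet measured in this assay. The change from compound 1 to compound 3 is methyl in place of hydrogen on a saturated chain carbon, three bonds along the chain from an aromatic carbon. Going by the values given here, no measured step touches that chain, so the one known step, which is a change on the aromatic ring, gives no guide to this change, and no step beyond the scatter is expected in either direction. For compound 3 the number in this assay is estimated to be 79 ug/mL, between 40 ug/mL and 160 ug/mL, which means an expected step of a 1.0-fold lower number from compound 1 to compound 3 (0.00 log units; within the scatter) of essentially no change.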

Compound 3, half-maximal cytotoxic concentration: 74.1 ug/mL
The estimate for compound 3 lay 1.1-fold (0.03 log units) above the measured number; the range from low to high includes it.
By their numbers in this assay, from the lowest: compounds 3, 1 and 2 (each within the scatter of the next).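

Going by these compounds alone, the chain, which no earlier step touched, now has a reading of its own: in this assay, methyl in place of hydrogen on a saturated chain carbon, three bonds along the chain from an aromatic carbon, gives a 1.1-fold lower number from compound 1 to compound 3 (0.03 log units; within the scatter) for this ethyl to propyl difference. At this position, then, the one added carbon leaves the number within the scatter, so both the ring and the chain have now been read once without a step beyond it. Nothing at hand offers an explanation for this reading.

From the compounds shown here alone, whether a longer chain such as butyl, or an amine or a carboxylic acid at this carbon, would also stay within the scatter remains open. Also open, going by these compounds, is whether the propyl chain would give the same reading alongside the methoxy group of compound 2.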